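This account rests on a few compounds, and the source may have more. Where it says the series, first, only, none or still open, it means among the compounds named here.

Measured so far:
compound 1 `Cc1cccc(N2CC(C)NC(=O)N2)c1` — 19000 nM
compound 2 `CC1CN(c2cccc(F)c2)NC(=O)N1` — 6300 nM
compound 3 `CC1CN(c2cccc(Cl)c2)NC(=O)N1` — 2700 nM

All three were run in an assay on RBL-1 cells for inhibition of Polyunsaturated fatty acid 5-lipoxygenase (Rattus norvegicus); a higher number here means a weaker inhibitor, a lower number a stronger inhibitor. Compound 3 gives the lowest of the three numbers; compound 2 sits nearest to it and compound 1 furthest. The steps among the three are all single swaps on the same aromatic carbon: a 3.0-fold lower number from compound 1 to compound 2 (0.48 log units; beyond the scatter), a 7.0-fold lower number from compound 1 to compound 3 (0.85 log units; beyond the scatter) and a 2.3-fold lower number from compound 2 to compound 3 (0.37 log units; beyond the scatter). Each is modest, each is beyond the scatter, and each exchanges one small substituent for another.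

Compound 4 `CC1CN(c2cccc(-c3cccs3)c2)NC(=O)N1` is the next member, not yet measured in this assay. It differs from compound 3 as follows: thiophen-2-yl in place of chloro on an aromatic carbon. For the measured compounds named here, none of the measured steps involves a ring entering in place of a single atom, so the three swaps bear on the question only in showing that this position tolerates change and that every exchange made there so far has moved the number. A step of modest size is therefore expected, and since each change at this carbon has so far lowered the number, the direction taken as more likely is downward, with wide uncertainty. The expected step is a 1.8-fold lower number from compound 3 to compound 4 (0.26 log units; within the scatter). For compound 4 the estimate in this assay is 1500 nM, with a range from 400 nM to 6000 nM.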

Compound 4, half-maximal inhibitory concentration: 2800 nM
Beside the measured number, compound 4's estimate is 1.9-fold (0.27 log units) below it, and the stated range covers the measured number.
By their numbers in this assay, from the lowest: compounds 3 and 4 (each within the scatter of the next); then compound 2; then compound 1.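

Working from this assay, thiophen-2-yl in place of chloro on this aromatic carbon gives a 1.0-fold higher number from compound 3 to compound 4 (0.02 log units; within the scatter) and is the first swap at this position whose step stays within the scatter, so a five-membered aromatic ring is accepted here where a single chlorine stood. The gain over the other two substituents survives the swap, with a 2.3-fold lower number from compound 2 to compound 4 (0.35 log units; beyond the scatter) for thiophen-2-yl in place of fluoro and a 6.8-fold lower number from compound 1 to compound 4 (0.83 log units; beyond the scatter) for thiophen-2-yl in place of methyl. Compound 3 and compound 4 therefore cannot be told apart in this series, even though the entering group is much larger than the chloro it replaces and carries a sulfur atom and a ring.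

Still open, as far as these compounds go, is whether this carbon would accept a phenyl ring, an amine, a carboxylic acid or a longer chain with the same result, and whether any group here can take the number beyond the scatter of compound 3 and compound 4. No supporting data bear on what lies behind the flat step from chloro to thiophen-2-yl.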